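The source may report more compounds than this note shows. Statements on the series, on what has been measured and on what is new or still open speak of the compounds shown alone.

Measured so far:
- compound 1 `CC1=CCC[C@H]2[C@](C)(CC3=CC(=O)C=C(N[C@@H](CC(C)C)C(=O)O)C3=O)[C@@H](C)CC[C@]12C`: 7720 nM
- compound 2 `CC1=CCC[C@H]2[C@](C)(CC3=CC(=O)C=C(NCCC(=O)O)C3=O)[C@@H](C)CC[C@]12C`: 8870 nM

For the measured compounds named here, in a functional assay on HeLa cells (Homo sapiens) for cytotoxicity, read by MTT assay, with a stated time of 72 h (on this read-out higher numbers stand for weaker inhibition and lower numbers for stronger inhibition), compound 2 gives 8870 nM, within the scatter of the only other measured value. Compound 3 `CC1=CCC[C@H]2[C@](C)(CC3=CC(=O)C=C(N[C@@H](C(=O)O)C(C)C)C3=O)[C@@H](C)CC[C@]12C` differs from compound 2 by 1-carboxy-2-methylpropyl in place of 2-carboxyethyl on an amine nitrogen. Going by the values given here, one measured step bears on this, a change on the same amine nitrogen: a 1.1-fold higher number from compound 1 to compound 2 (0.06 log units; within the scatter). No change beyond the scatter is therefore expected in this assay. The expected step, a 1.1-fold lower number from compound 2 to compound 3 (0.04 log units; within the scatter), stays within the scatter. The estimated value for compound 3 is 8000 nM, with a range of 4000 nM to 16000 nM.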

Compound 3, half-maximal inhibitory concentration: 10900 nM
Estimate against measurement, compound 3: 1.4-fold (0.13 log units) below; the range from low to high includes it.
By their numbers in this assay, from the lowest: compounds 1, 2 and 3 (each within the scatter of the next).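

In this assay, the new group on this amine nitrogen gives a 1.2-fold higher number from compound 2 to compound 3 (0.09 log units; within the scatter) and a 1.4-fold higher number from compound 1 to compound 3 (0.15 log units; within the scatter). Swapping among 2-carboxyethyl, 1-carboxy-3-methylbutyl and 1-carboxy-2-methylpropyl therefore does not separate these compounds in this assay, whether or not the group carries a defined stereocentre. No outside data bear on this result.

On these data alone, all three groups keep a carboxylic acid, so the effect of an ester, an amide or a simple alkyl chain on this nitrogen stays open. As far as these compounds go, the opposite stereocentre configuration in these groups also stays open.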